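The compounds below may be only part of what the source reports. "The series", "measured", "known", "first", "only" and "open" are said of these compounds alone.

Compound 1 has the structure `O=C1OC(Cc2nc(-c3ccccc3)no2)c2ccccc21`. In an ADME assay on RAW264.7 cells (Mus musculus) for cytotoxicity, read by MTT assay, with a stated time of 24 h, in the absence of a further agent (a lower number here means a stronger inhibitor, a higher number a weaker inhibitor), compound 1 gives > 40000 nM, which is a limit of the assay.
Compound 2 has the structure `CCCCCCOc1ccc(C(O)C2OC(=O)c3c(OC)cc(OC)cc32)cc1`. In this assay compound 2 gives > 40000 nM, again a limit.
Compound 3 has the structure `CCC(C)Oc1ccc(C(O)C2OC(=O)c3c(OC)cc(OC)cc32)cc1`. In this assay compound 3 gives > 40000 nM, also a limit.

Compound 2 therefore stands at a limit only, and the two other measured values are limits as well, so no measured value in this assay places any compound relative to another. For the measured compounds named here, the single step between measured compounds, a step that the two limits leave unreadable from compound 2 to compound 3, is left unreadable by the two limits. All three values sit at the limit of > 40000 nM in this assay, at which 3 of the 3 values shown sit.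

Compound 4 has the structure `COc1cc(OC)c2c(c1)C(C(O)c1ccc(OCc3ccc(Cl)cc3)cc1)OC2=O`. It differs from compound 2 by 4-chlorophenyl in place of pentyl on a saturated chain carbon bound to an oxygen on an aromatic ring. Going by the values given here, the one measured step, from compound 2 to compound 3, changed the chain on the same oxygen and gave no readable size, so no measured step bears on the change to compound 4 in a way that can be read. Compound 4 is therefore expected to remain at the limit, with a step that the limit leaves unreadable from compound 2 to compound 4 expected to be no step beyond the scatter. The estimate for compound 4 in this assay is 45000 nM, with a range from 20000 nM to 100000 nM.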

Compound 4, half-maximal inhibitory concentration: > 40000 nM
Compound 4: a limit, no number; the forecaster's own chance of this, stated with the estimate: 85%; the middle value is on the limit's open side.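

Compound 4 also gives only a limit in this assay, so its steps from compound 2 and from compound 3 cannot be read: the limit of > 40000 nM in this assay, at which 4 of the 4 values shown sit.

The compounds shown leave open whether any change to the group on the oxygen on the aromatic ring alters the value in this assay at all.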